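Swapping the Aromatic Ring on a Hydroxamic Acid Chain

The compounds below may be only part of what the source reports. "The series", "measured", "known", "first", "only" and "open" are said of these compounds alone.

For the measured compounds named here, compound 1 `O=C(CCCCCCC(=O)Nc1nnc(-c2ccncc2)s1)NO` was tested in a functional assay on MDA-MB-231 cells (Homo sapiens) for antiproliferative activity, read by MTT assay, with a stated time of 48 h (on this read-out higher numbers stand for weaker inhibition and lower numbers for stronger inhibition), and gives 4690 nM, the lowest of the two numbers measured so far. Going by the values given here, its only measured neighbour is compound 2 `O=C(CCCCCC(=O)Nc1nnc(-c2ccncc2)s1)NO`, which in this assay gives 40100 nM; the single recorded step is an 8.6-fold higher number from compound 1 to compound 2 (0.93 log units; beyond the scatter), and it concerns only the length of the saturated chain.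

Compound 3 `O=C(CCCCCCC(=O)Nc1nnc(-c2cccs2)s1)NO` has not yet been measured. It differs from compound 1 in one place: thiophen-2-yl in place of pyridin-4-yl on an aromatic carbon. Among the compounds with values here, no measured pair shows what exchanging this aromatic group does, since the one recorded step leaves the aromatic group untouched and alters the chain instead. With no bearing evidence, the expected change from compound 1 to compound 3 in this assay is none beyond the scatter, expressed as a 1.1-fold higher number from compound 1 to compound 3 (0.03 log units; within the scatter). Compound 3 is therefore estimated to give 5000 nM in this assay, with a wide range from 1500 nM to 17000 nM.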

Compound 3, half-maximal inhibitory concentration: 1210 nM
Compound 3: the middle estimate sits 4.1-fold (0.62 log units) above what was measured, outside the stated range (below it).
By their numbers in this assay, from the lowest: compound 3; then compound 1; then compound 2.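

In this assay, thiophen-2-yl in place of pyridin-4-yl gives a 3.9-fold lower number from compound 1 to compound 3 (0.59 log units; beyond the scatter), so the aromatic group on this carbon of the shared core does matter for the read-out. The earlier step changed only the chain and could not show this: the group at this position can now be seen to shift the number on its own, with the chain held fixed. No evidence at hand says why the number falls with this exchange.

Going by these compounds, whether the same exchange would lower the number on the shorter chain of compound 2 remains open. Also open, on these data alone, is how other aromatic groups at this position, such as phenyl or furan-2-yl, would compare, so two groups alone cannot yet describe a trend.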